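A Chloro and Trifluoromethyl Isomer Awaiting Its Number

This account rests on a few compounds, and the source may have more. Where it says the series, first, only, none or still open, it means among the compounds named here.

Of the compounds shown here, three have values so far in a functional assay on A549 cells (Homo sapiens) for antiproliferative activity, read by spectrophotometry, with a stated time of 2 days (on this read-out higher numbers stand for weaker inhibition of growth and lower numbers for stronger inhibition of growth), on this core.

Compound 1 `Cc1ccc(Nc2ncc(C(F)(F)F)c(N3Cc4cccc(N(C)S(C)(=O)=O)c4C3)n2)cc1C` gives > 30000 nM (a limit)
Compound 2 `Cc1ccc(Nc2ncc(C(F)(F)F)c(N3Cc4cccc(N(C)S(C)(=O)=O)c4C3)n2)c(C)c1` gives 20700 nM (a number)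
Compound 3 `CN(c1cccc2c1CN(c1nc(Nc3ccc(Cl)c(C(F)(F)F)c3)ncc1C(F)(F)F)C2)S(C)(=O)=O` gives 15200 nM (a number)

Compound 3 has no clear lead on these numbers, since the data show only a 1.4-fold lower number from compound 2 to compound 3 (0.13 log units; within the scatter) between the two measured values. Both an at least 1.4-fold lower number from compound 1 to compound 2 (0.16 log units; that floor lies within the scatter) and an at least 1.9-fold lower number from compound 1 to compound 3 (0.29 log units; that floor lies within the scatter) are floors and nothing firmer.

Compound 4 `CN(c1cccc2c1CN(c1nc(Nc3cc(Cl)cc(C(F)(F)F)c3)ncc1C(F)(F)F)C2)S(C)(=O)=O` differs from compound 3 in one place 3-chloro-5-(trifluoromethyl)phenyl in place of 4-chloro-3-(trifluoromethyl)phenyl on a nitrogen on an aromatic ring and carries 3-chloro-5-(trifluoromethyl)phenyl in place of 4-chloro-3-(trifluoromethyl)phenyl on a nitrogen on an aromatic ring. All three measured steps change the group at this same place, though none swaps these two groups. Since changing the group on compound 2 gave only a 1.4-fold lower number from compound 2 to compound 3 (0.13 log units; within the scatter) here, a shift beyond the scatter is not expected in this assay for this isomer. The expected step is a 1.0-fold lower number from compound 3 to compound 4 (0.01 log units; within the scatter) by this estimate. Compound 4 is estimated at 15000 nM (range 6000 nM to 30000 nM).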

Compound 4, concentration for 50% growth inhibition: 6700 nM
Estimate against measurement, compound 4: 2.2-fold (0.35 log units) above; the measured number falls inside the stated range.
By their numbers in this assay, from the lowest: compound 4; then compounds 3 and 2 (each within the scatter of the next). At a limit, above all of these: compound 1.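

In this assay, no earlier change of the group on a nitrogen on an aromatic ring had given a step shown to lie beyond the scatter, but exchanging 4-chloro-3-(trifluoromethyl)phenyl for 3-chloro-5-(trifluoromethyl)phenyl, with the same atoms joined differently, gives a 2.3-fold lower number from compound 3 to compound 4 (0.36 log units; beyond the scatter). The same group also clears the scatter against both dimethylphenyl groups, with a 3.1-fold lower number from compound 2 to compound 4 (0.49 log units; beyond the scatter) and an at least 4.4-fold lower number from compound 1 to compound 4 (0.65 log units; beyond the scatter). Compound 1 is held at a limit and not a number, so the last of these steps is only a floor: the limit of > 30000 nM in this assay, at which 1 of the 4 values shown sits.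

As far as these compounds go, whether a nitrile or a methoxy group could stand in for the chlorine of 3-chloro-5-(trifluoromethyl)phenyl and keep this step remains open. All four compounds also share one core, so the compounds shown cannot tell whether the step would hold on another core.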